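Trimming the Amine Substituent of Compound 1

The compounds below may be only part of what the source reports. "The series", "measured", "known", "first", "only" and "open" are said of these compounds alone.

Compound 1 `Cc1ccc(S(=O)(=O)/N=C(/CCNC2=CC(=O)c3ccccc3C2=O)Nc2ccc(Cl)cc2)cc1` gives the smallest of the three numbers shown in an ADME assay on HEK293 cells (Homo sapiens) for cytotoxicity, read by MTT assay, with a stated time of 48 h (a lower number here means a stronger inhibitor, a higher number a weaker inhibitor), at 65400 nM, though both of its steps to the others stay within the scatter: compound 3 `Cc1ccc(S(=O)(=O)/N=C(/CCNC2=CC(=O)c3ccccc3C2=O)NC(C)C)cc1` gives 71600 nM and compound 2 `Cc1ccc(S(=O)(=O)/N=C(/CCNC2=CC(=O)c3ccccc3C2=O)Nc2cccc(C(F)(F)F)c2)cc1` gives 91500 nM. The measured steps of a 1.4-fold higher number from compound 1 to compound 2 (0.15 log units; within the scatter), a 1.1-fold higher number from compound 1 to compound 3 (0.04 log units; within the scatter) and a 1.3-fold lower number from compound 2 to compound 3 (0.11 log units; within the scatter) all lie within the scatter. Compound 4 `Cc1ccc(S(=O)(=O)/N=C(\N)CCNC2=CC(=O)c3ccccc3C2=O)cc1` differs from compound 1 in one place: hydrogen in place of 4-chlorophenyl on an amine nitrogen. Since every measured exchange at this amine nitrogen left the number within the scatter, compound 4 is expected to show a step of a 1.1-fold higher number from compound 1 to compound 4 (0.03 log units; within the scatter) that also stays within it. Compound 4 is therefore estimated at 70000 nM, within the range 38000 nM to 130000 nM.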

Compound 4, half-maximal inhibitory concentration: 63100 nM
For compound 4 the middle estimate is 1.1-fold (0.05 log units) above the measured one; low and high end bracket the measured number.
By their numbers in this assay, from the lowest: compounds 4, 1, 3 and 2 (each within the scatter of the next).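

With only hydrogen on the amine nitrogen, the number in this assay stays within the scatter of all three substituted compounds, with a 1.0-fold lower number from compound 1 to compound 4 (0.02 log units; within the scatter) and a 1.1-fold lower number from compound 3 to compound 4 (0.05 log units; within the scatter) and a 1.5-fold lower number from compound 2 to compound 4 (0.16 log units; within the scatter) as the steps. Going by these compounds alone, the earlier compounds all carried a substituent here, so this is the first sign that the number does not depend on having one at this position. No evidence is available to explain this result. As far as these compounds go, whether a carboxylic acid or a longer chain on this nitrogen would also stay within the scatter remains open, as does whether an exchange elsewhere in the shared core would move the number.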